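The compounds below may be only part of what the source reports. "The series", "measured", "known", "first", "only" and "open" are said of these compounds alone.

Working notes on the series.

The series shares one core, seen in compound 1 `COc1cc2oc(-c3cccc(NC(=O)c4ccc(Br)cc4)c3)cc(=O)c2c(OC)c1OC`, whose pendant aryl carries an amide. In a functional assay on UO-31 cells (Homo sapiens) for inhibition, read by sulforhodamine B assay, tested at 10 uM (a lower number here means less inhibition, a higher number more inhibition at the concentration tested (going by the name of the read-out)), compound 1 gives 63.6%. Compound 2 `COc1cc2oc(-c3ccc(NC(=O)c4ccc(C)cc4)cc3)cc(=O)c2c(OC)c1OC` moves the amide to a different position on the pendant aryl and carries a methyl-bearing phenyl on the carbonyl; in this assay compound 2 gives "active" (no number reported), with no number, so it cannot be placed on the scale by itself. Compound 3 `COc1cc2oc(-c3ccc(NC(=O)c4cccc(Br)c4)cc3)cc(=O)c2c(OC)c1OC` keeps the skeleton of compound 2 and changes one group (3-bromophenyl in place of 4-methylphenyl on a carbonyl carbon). Going by the values given here, no measured pair spans this change, so no size of step can be read from the data; with compound 2 unnumbered, the only anchor is compound 1, which also carries a bromine on that phenyl. On that basis compound 3 is expected to give about 58% in this assay, within a range of 30% to 82%.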

Compound 3, a percentage reported as inhibition, at one concentration (the size of the read-out at that concentration, not a potency): "active" (no number reported)
Compound 3 has no reported number here; no gap can be computed for the estimate.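

Compound 2 and compound 3 are both reported only as "active", with no number, so no step can be read between them. The compounds shown leave open how far 3-bromophenyl in place of 4-methylphenyl on the carbonyl carbon shifts inhibition. No supporting evidence bears on this result.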